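A few compounds are considered here, and "the series" means these few. Any claim that something is new, unique, unknown or untested is made for them only; others in the source may bear on it.

Measured in a functional assay on PC-12 cells (Rattus norvegicus) for cytotoxicity, read by MTT assay, with stated times of 2 h and 24 h, tested at 1 uM; on this read-out lower numbers stand for a weaker effect and higher numbers for a stronger effect at the one concentration tested:

Compound 1 `Cc1ccc(-n2nc(-c3ccc(C(F)(F)F)cc3O)nc2-c2ccccc2O)cc1` — compound 1 gives 71.5%
Compound 2 `Oc1cc(C(F)(F)F)ccc1-c1nc(-c2ccccc2O)n(-c2ccccc2F)n1` — compound 2 gives 63.4%
Compound 3 `Oc1cc(C(F)(F)F)ccc1-c1nc(-c2ccccc2O)n(-c2ccccc2Cl)n1` — compound 3 gives 70.1%

On the numbers shown, compound 1 holds the highest of the three, but neither gap separates it from the others: the nearest, compound 3, lies a number 1.4 percentage points lower from compound 1 to compound 3 (within the scatter), and the furthest, compound 2, lies a number 8.1 percentage points lower from compound 1 to compound 2 (within the scatter). Between the two halogenated analogues the picture is the same, with a number 6.7 percentage points higher from compound 2 to compound 3 (within the scatter).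

Compound 4 `Oc1cc(C(F)(F)F)ccc1-c1nc(-c2ccccc2O)n(-c2ccc(Cl)cc2Cl)n1` has not been measured. Relative to compound 1 it carries 2,4-dichlorophenyl in place of 4-methylphenyl on an aromatic nitrogen. Among the compounds with values here, the steps that bear on this change are the two earlier swaps of the group on the same aromatic nitrogen, from compound 1 to compound 2 and from compound 1 to compound 3, together with the exchange of chloro for fluoro from compound 2 to compound 3. All three stayed within the scatter, so there is no indication in this set that varying this aryl group moves the read-out, and a step of no size beyond the scatter is expected for compound 4 in this assay.

Compound 4 is therefore estimated to give 68%, within 55% to 80%, which would mean an expected step of a number 3.5 percentage points lower from compound 1 to compound 4 (within the scatter).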

Compound 4, a percentage reported as activity, at one concentration (the size of the read-out at that concentration, not a potency): 69%
Compound 4: middle estimate off by 1 percentage points, on the low side; low and high end bracket the measured number.
By their numbers in this assay, from the lowest: compounds 2, 4, 3 and 1 (each within the scatter of the next).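

In this assay, within the data shown here, the swap of 4-methylphenyl for 2,4-dichlorophenyl on the aromatic nitrogen gives a number 2.5 percentage points lower from compound 1 to compound 4 (within the scatter) and so extends the earlier result to an aryl group carrying two chlorine atoms, the first such group in this set. Among these compounds, the added chloro, in place of hydrogen on an aromatic carbon, gives a number 1.1 percentage points lower from compound 3 to compound 4 (within the scatter) and is the first step here to add a substituent to the aryl ring rather than exchange one, yet it does not separate the two compounds. The exchange of 2-fluorophenyl for 2,4-dichlorophenyl gives a number 5.6 percentage points higher from compound 2 to compound 4 (within the scatter) and likewise leaves those two compounds inseparable, so all four aryl groups on this nitrogen now fall within the scatter of one another. No independent measurement is available that bears on this result.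

The compounds shown leave open whether an amine or a carboxylic acid on this aryl ring, or a longer alkyl chain in its place on the nitrogen, would separate from these values. They also leave open what happens when the trifluoromethyl or either hydroxyl group of the shared core is replaced, since all four compounds carry them unchanged.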